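The source may hold more compounds than are shown below. What is called first, only, known or untested is meant among the compounds shown, and "the series" means these compounds.

Working notes on the ring-nitrogen substituent of the pyrrolidine amide.

For the measured compounds named here, compound 3 `CN1CCC[C@H]1C(=O)N1CCC(NS(=O)(=O)c2cc(S(=O)(=O)c3ccccc3)ccc2C(F)(F)F)CC1` carries a methyl on that nitrogen; in an assay on isolated protein for binding affinity to secreted frizzled-related protein 1 (Homo sapiens), read by fluorescence (a lower number here means a stronger inhibitor, a higher number a weaker inhibitor), compound 3 gives 120 nM, the highest of the three numbers so far. Compound 1 `O=C1CC[C@@H](C(=O)N2CCC(NS(=O)(=O)c3cc(S(=O)(=O)c4ccccc4)ccc3C(F)(F)F)CC2)N1` gives 90 nM, and the step of a 1.3-fold higher number from compound 1 to compound 3 (0.12 log units; within the scatter). Compound 2 `CCNC(=O)N1CCC[C@H]1C(=O)N1CCC(NS(=O)(=O)c2cc(S(=O)(=O)c3ccccc3)ccc2C(F)(F)F)CC1` gives 30 nM; the step of a 3.0-fold lower number from compound 1 to compound 2 (0.48 log units; beyond the scatter) and the step of a 4.0-fold higher number from compound 2 to compound 3 (0.60 log units; beyond the scatter) show that changes at this nitrogen have moved the number by modest amounts in both directions.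

Compound 4 `CC(C)(C)CCN1CCC[C@H]1C(=O)N1CCC(NS(=O)(=O)c2cc(S(=O)(=O)c3ccccc3)ccc2C(F)(F)F)CC1` differs from compound 3 by neopentyl in place of hydrogen on a saturated chain carbon bound to an amine nitrogen in a ring. Going by the values given here, no measured step extends a saturated chain on this nitrogen; the two steps that touch the position are those from compound 1 and compound 2 to compound 3, both modest. A step of at most that size is therefore expected, with no clear direction favoured. This corresponds to an expected step of a 1.2-fold lower number from compound 3 to compound 4 (0.08 log units; within the scatter). For compound 4 the estimate is 100 nM. The range expected for compound 4 runs from 40 nM to 250 nM.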

Compound 4, half-maximal inhibitory concentration in the secreted frizzled-related protein 1 assay: 30 nM
The estimate for compound 4 lay 3.3-fold (0.52 log units) above the measured number; the measured number lies below the stated range.
By their numbers in the secreted frizzled-related protein 1 assay, from the lowest: compounds 2 and 4 (each within the scatter of the next); then compounds 1 and 3 (each within the scatter of the next).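

For the compounds shown here, in the secreted frizzled-related protein 1 assay the change from methyl to 3,3-dimethylbutyl on the amine nitrogen in the ring gives a 4.0-fold lower number from compound 3 to compound 4 (0.60 log units; beyond the scatter) and thus shows that this position tolerates a saturated chain, which the earlier compounds left untested. In the secreted frizzled-related protein 1 assay that chain matches ethylcarbamoyl, with no change at the digits printed from compound 2 to compound 4 (within the scatter) on that exchange, and the comparison with the 5-oxopyrrolidin-2-yl amide gives a 3.0-fold lower number from compound 1 to compound 4 (0.48 log units; beyond the scatter) as its result. In a physicochemical assay for solubility (on this read-out higher numbers stand for higher solubility and lower numbers for lower solubility), compound 3 gives 100000 nM and compound 4 gives 12500 nM. The same change carries a cost in the physicochemical assay: the measured solubility of compound 3, 100000 nM, and of compound 4, 12500 nM, an 8.0-fold lower number (0.90 log units; beyond the scatter).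

A single long chain cannot show whether the number in the secreted frizzled-related protein 1 assay follows chain length or branching. A propyl chain, or a chain ending in an amine or a carboxylic acid, would test whether the lower number can be kept without the loss in the physicochemical assay seen for this chain.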